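The source may report more compounds than this note shows. Statements on the series, on what has been measured and on what is new or still open speak of the compounds shown alone.

Measured compounds:
- compound 1, `CC(C)=CCc1cc(C(=O)Nc2cc3ccc(OCCCNC(C)(C)C)c(C)c3oc2=O)ccc1O`: 660 nM
- compound 2, `COC(=O)CNCCCOc1ccc2cc(NC(=O)c3ccc(O)c(CC=C(C)C)c3)c(=O)oc2c1C`: 1060 nM

In a functional assay on SK-BR-3 cells (Homo sapiens) for antiproliferative activity (on this read-out lower numbers stand for stronger inhibition and higher numbers for weaker inhibition), compound 2 gives 1060 nM, the highest of the two numbers recorded. Its nearest neighbour is compound 1, which in this assay gives 660 nM; the difference between them, a 1.6-fold higher number from compound 1 to compound 2 (0.21 log units; within the scatter), is within the scatter, so the two cannot be ordered.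

Compound 3, `CC(C)=CCc1cc(C(=O)Nc2cc3ccc(OCCCN[C@@H]4C[C@H]5CC[C@@H]4C5)c(C)c3oc2=O)ccc1O`, has not yet been measured. It differs from compound 2 in one place: a group of 7 heavy atoms (7 carbon; 2 five-membered non-aromatic rings of carbon only) in place of a group of 5 heavy atoms (3 carbon, 2 oxygen; no ring), on an amine nitrogen. Among the compounds with values here, the only measured step at this position is the one from tert-butyl to (methoxycarbonyl)methyl, a 1.6-fold higher number from compound 1 to compound 2 (0.21 log units; within the scatter), and it stayed within the scatter. That step therefore suggests that exchanging the group on this amine nitrogen moves the number little. The entering group of compound 3 resembles the tert-butyl of compound 1 in carrying no oxygen and no hydrogen-bond acceptors, so the number of compound 1, 660 nM, is taken as the closer guide. The expected step is a 1.6-fold lower number from compound 2 to compound 3 (0.21 log units; within the scatter), a small movement towards a lower number that may not exceed the scatter. Compound 3 is thus estimated at 650 nM, with a range from 250 nM to 1700 nM.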

Compound 3, half-maximal inhibitory concentration: 770 nM
Compound 3: the middle estimate sits 1.2-fold (0.07 log units) below what was measured, within the range that was stated.
By their numbers in this assay, from the lowest: compounds 1, 3 and 2 (each within the scatter of the next).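

Within the data shown here, compound 3 brings the first group with rings to this amine nitrogen, a group of 7 heavy atoms with 2 five-membered non-aromatic rings of carbon only and 3 defined stereocentres. In this assay, replacing the (methoxycarbonyl)methyl gives a 1.4-fold lower number from compound 2 to compound 3 (0.14 log units; within the scatter) and replacing the tert-butyl gives a 1.2-fold higher number from compound 1 to compound 3 (0.07 log units; within the scatter) and so neither exchange separates the compounds. The earlier pair had shown this only for two groups without a ring, whereas these three compounds show that a group with rings and no oxygen also cannot be ordered against either of them, and nothing available here accounts for this flatness.

As far as these compounds go, it remains open whether a carboxylic acid in place of the methyl ester, an unsubstituted amine, or a phenyl group on this nitrogen would also stay within the scatter of these three compounds. Also open, from the compounds shown here alone, are how the other stereoisomers of the entering group would read in this assay and whether a longer chain leading to this amine nitrogen would change the picture.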